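A few compounds are considered here, and "the series" means these few. Any claim that something is new, unique, unknown or untested is made for them only; others in the source may bear on it.

The series shares a core with a chain ending in a thioamide-type group. Compound 1 `N=C(S)CCCn1nc(-c2ccccc2)ccc1=O` gives 31.9 mg/kg in a functional assay on the whole organism (stomach) with Rattus norvegicus as the target; a lower number here means that less compound is needed, a higher number that more compound is needed for the effect. Within the data shown here, compound 2 `C/N=C(\S)CCn1nc(-c2ccccc2)ccc1=O` gives 58.5 mg/kg in this assay, and the single measured step, a 1.8-fold higher number from compound 1 to compound 2 (0.26 log units; within the scatter), concerns the chain end and not the ring substituent. Compound 3 `Cc1ccc(=O)n(CCCCCCC(=N)S)n1` carries the methyl on the core and the long chain; in this assay compound 3 returns only a limit, > 100 mg/kg, so its place among the numbers is known only as one that sits at the limit (the limit of > 100 mg/kg in this assay, at which 1 of the 3 values shown sits).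

Compound 4 `N=C(S)CCCCCCn1nc(-c2ccccc2)ccc1=O` differs from compound 3 by phenyl in place of methyl on an aromatic carbon. Among the measured compounds shown here, no measured step covers this exchange, so only the two phenyl-bearing compounds, compound 1 at 31.9 mg/kg and compound 2 at 58.5 mg/kg, both with shorter chains, give any anchor. On that footing compound 4 is expected to fall near 60 mg/kg, within 25 mg/kg to 150 mg/kg, which would mean an estimated step of an at least 1.6-fold lower number from compound 3 to compound 4 (0.22 log units; that floor lies within the scatter), with a real chance that this assay again reports only a limit.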

Compound 4, dose for half-maximal effect: > 100 mg/kg
Compound 4 ended at the assay's limit; the forecaster's own chance of this, stated with the estimate: 40%; middle value at least 1.6-fold (0.22 log units) from the limit.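

In this assay, the longer chain on the phenyl-bearing core now has a readable cost: an at least 3.1-fold higher number from compound 1 to compound 4 (0.49 log units; beyond the scatter). The comparison with compound 2 is weaker, as its floor does not clear the scatter: an at least 1.7-fold higher number from compound 2 to compound 4 (0.23 log units; that floor lies within the scatter). Compound 4 returns a limit, as compound 3 does, so the step for phenyl in place of methyl on an aromatic carbon cannot be read: the limit of > 100 mg/kg in this assay, at which 2 of the 4 values shown sit.

Open, going by these compounds, is where, at chain lengths between those of compound 1 and compound 4, the number begins to rise. Also open, on these data alone, are whether methyl in place of phenyl matters on the shorter chain of compound 1, and whether an amine or a carboxylic acid at the chain end would keep the effect.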